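Azetidine sulfonamide series: methyl for chloro on the aryl

The source may hold more compounds than are shown below. What is called first, only, known or untested is meant among the compounds shown, and "the series" means these compounds.

Measured so far in an assay on HEK293 cells for positive allosteric modulation of metabotropic glutamate receptor 5 (Homo sapiens), read by FLIPR; on this read-out lower numbers stand for an effect already at smaller amounts and higher numbers for an effect only at larger amounts of compound:
compound 1 `Cc1cccc(-c2noc(C3CN(S(=O)(=O)c4cccc(C)c4)C3)n2)c1` gives > 10000 nM, a limit of the assay, not a number.
compound 2 `O=S(=O)(c1ccc(F)cc1)N1CC(c2nc(-c3cccc(Cl)c3)no2)C1` gives > 10000 nM, a limit of the assay.
compound 3 `O=S(=O)(c1ccc(Cl)cc1)N1CC(c2nc(-c3cccc(Cl)c3)no2)C1` gives > 10000 nM, a limit of the assay.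

Compound 3 thus stands at the same limit as the other two measured compounds; its value is a limit and not a number. Going by the values given here, the one step among measured compounds is a step that the two limits leave unreadable from compound 2 to compound 3, so its size cannot be read. Among the compounds with values here, this is what the limit of > 10000 nM in this assay, at which 3 of the 3 values shown sit, tells: every value sits at that limit, and no measured step is readable.

Compound 4 `Cc1cccc(-c2noc(C3CN(S(=O)(=O)c4ccc(Cl)cc4)C3)n2)c1` is to be measured in this assay. It differs from compound 3 by methyl in place of chloro on an aromatic carbon. Within the data shown here, no measured step bears on this change directly. Compound 1, which carries the same 3-methylphenyl group as compound 4, sits at the limit, and compound 3, which shares the sulfonyl aryl group of compound 4, sits at the limit too. Compound 4 is therefore expected to remain at the limit, with no readable step from compound 3: the estimated step is a step that the limit leaves unreadable from compound 3 to compound 4. For compound 4 the estimate in this assay is 20000 nM, within 8000 nM to 50000 nM.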

Compound 4, half-maximal effective concentration: > 10000 nM
Compound 4 gave a limit, no number; the forecaster's own chance of this, stated with the estimate: 85%; the middle value lies beyond the limit too.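

In this assay compound 4 gives > 10000 nM, a limit of the assay and not a number. Neither the step between compound 3 and compound 4 nor that between compound 1 and compound 4 can be read: the limit of > 10000 nM in this assay, at which 4 of the 4 values shown sit.

The compounds shown leave open how methyl and chloro compare on the aromatic ring, since none yields a number in this assay.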